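A swap on the sulfonyl sulfur of compound 3

A few compounds are considered here, and "the series" means these few. Any claim that something is new, unique, unknown or untested is made for them only; others in the source may bear on it.

- Compound 1 `COc1ccc([C@H]2CC(=O)N(c3cccc(NCc4ccoc4)c3)C2)cc1OC1CCCC1`: > 10000 nM (a limit)
- Compound 2 `COc1ccc(OC)c(S(=O)(=O)Nc2cccc(N3C[C@@H](c4ccc(OC)c(OC5CCCC5)c4)CC3=O)c2)c1`: 7590 nM
- Compound 3 `COc1ccc([C@H]2CC(=O)N(c3cccc(NS(=O)(=O)c4cccc(Cl)c4)c3)C2)cc1OC1CCCC1`: > 10000 nM (a limit)

All of these results come from a functional assay on HEK293 cells (Homo sapiens) for cytotoxicity; on this read-out lower numbers stand for higher toxicity in this test and higher numbers for lower toxicity in this test. Compound 3 reads > 10000 nM, which is a limit and not a number. Compound 3 thus shares (the limit of > 10000 nM in this assay, at which 2 of the 3 values shown sit).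

Compound 4 `COc1ccc([C@H]2CC(=O)N(c3cccc(NS(=O)(=O)c4ccc(F)cc4)c3)C2)cc1OC1CCCC1` carries 4-fluorophenyl in place of 3-chlorophenyl on a sulfonyl sulfur. The closest guide is a change at that same place, an at least 1.3-fold higher number from compound 2 to compound 3 (0.11 log units; that floor lies within the scatter). The other measured step, a step that the two limits leave unreadable from compound 1 to compound 3, gives no size to work with. With only these steps as a guide, the swap is not expected to move the read-out much, and the result may again be reported only as a limit. The estimate is therefore a number no higher from compound 3 to compound 4 (the limit leaves the size open), which is expected to be no step beyond the scatter. For compound 4 the expected value is 10000 nM, with an estimated range of 6000 nM to 20000 nM.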

Compound 4, half-maximal cytotoxic concentration: > 10000 nM
Compound 4: a limit, no number; the forecaster's own chance of this, stated with the estimate: 75%; the middle value sits exactly at the limit.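

In this assay compound 4 reads > 10000 nM, which is a limit, and it joins the other compounds there: the limit of > 10000 nM in this assay, at which 3 of the 4 values shown sit.

The sulfonyl sulfur now carries a second group, 4-fluorophenyl, that ends at the same limit as 3-chlorophenyl, and the steps to compound 4 from compound 3 and from compound 1 join two limits and cannot be read. Going by these compounds alone, the only readable step is an at least 1.3-fold higher number from compound 2 to compound 4 (0.11 log units; that floor lies within the scatter), so no difference beyond the scatter can be claimed for 4-fluorophenyl against 2,5-dimethoxyphenyl.

On these data alone, how far compound 3 and compound 4 lie past the limit stays unknown, and so does whether the fluorine or chlorine matters at all in this test. Also open, as far as these compounds go, is whether an amine or a carboxylic acid on that aromatic ring, or a plain methyl group in its place, would bring the read-out down to a measurable number.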